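The compounds below may be only part of what the source reports. "The series", "measured", "known", "first", "only" and "open" are said of these compounds alone.

Compound 1 `COc1c(Br)cc(Br)cc1C(=O)Nc1ccccc1` is the smallest member of the set. In an assay for inhibition of HSP60/HSP10 (Homo sapiens), with a stated time of 60 min (a lower number here means a stronger inhibitor, a higher number a weaker inhibitor), compound 1 gives > 100000 nM, which is a limit of the assay and not a number. Compound 2 `COc1ccc(Br)cc1C(=O)Nc1ccc(Sc2nc3ccccc3s2)cc1` carries the same 5-bromo-2-methoxyphenyl group on a larger amide. In this assay compound 2 gives > 100000 nM, again a limit of the assay rather than a measured number. Within the data shown here, compound 3 `O=C(Nc1ccc(Sc2nc3ccccc3s2)c(Cl)c1)c1cccc(Br)c1O` is the only member with a figure: in this assay compound 3 gives 6900 nM. Compound 2 therefore stands at the limit of the range, a position shared with compound 1 (the limit of > 100000 nM in this assay, at which 2 of the 3 values shown sit), and the data show nothing that orders compound 1 and compound 2 against each other.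

Compound 4 `COc1ccccc1C(=O)Nc1ccc(Sc2nc3ccccc3s2)cc1` differs from compound 2 by hydrogen in place of bromo on an aromatic carbon. No measured pair in the set isolates this change, so the size of the step cannot be read from the compounds shown. With compound 2 already at the limit, the author expects compound 4 to remain there as well, so the expected step that the limit leaves unreadable from compound 2 to compound 4 is essentially none beyond the scatter. The estimate for compound 4 in this assay is 200000 nM, within a range from 50000 nM to 1000000 nM, and most likely reported once more only as a limit.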

Compound 4, half-maximal inhibitory concentration: > 100000 nM
Compound 4: no number, only a limit; the forecaster's own chance of this, stated with the estimate: 85%; the middle value is on the limit's open side.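

Compound 2 and compound 4 both stand at a limit of the assay and not at a number, so no step can be read between them, because neither limit gives a size: the limit of > 100000 nM in this assay, at which 3 of the 4 values shown sit. The compounds shown leave open whether hydrogen in place of bromo on an aromatic carbon changes inhibition at all.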